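A few compounds are considered here, and "the series" means these few. Any claim that something is new, unique, unknown or untested is made for them only; others in the source may bear on it.

Compound 3, `CC(C(=O)NCc1ccc(C(F)(F)F)cc1N1CCN(c2ccccc2)CC1)c1ccc(NS(C)(=O)=O)c(F)c1`, is one of three analogues that share a core and differ only in the group carried on one aromatic carbon. In an assay on CHO cells for antagonist activity at transient receptor potential cation channel subfamily V member 1 (Homo sapiens), read by FLIPR (on this read-out higher numbers stand for weaker inhibition and lower numbers for stronger inhibition), compound 3 gives 2 nM; compound 1, `CCCN(CCC)c1cc(C(F)(F)F)ccc1CNC(=O)C(C)c1ccc(NS(C)(=O)=O)c(F)c1`, gives 0.3 nM, and compound 2, `CCC1CCN(c2cc(C(F)(F)F)ccc2CNC(=O)C(C)c2ccc(NS(C)(=O)=O)c(F)c2)CC1`, gives 0.7 nM. Compound 3 thus stands highest of the three: the step is a 6.7-fold higher number from compound 1 to compound 3 (0.82 log units; beyond the scatter) and a 2.9-fold higher number from compound 2 to compound 3 (0.46 log units; beyond the scatter), while the two amines differ by a 2.3-fold higher number from compound 1 to compound 2 (0.37 log units; beyond the scatter). Compound 4, `CC(C(=O)NCc1ccc(C(F)(F)F)cc1OCc1ccc(F)cc1)c1ccc(NS(C)(=O)=O)c(F)c1`, carries a change at the same aromatic carbon: (4-fluorobenzyl)oxy in place of 4-phenylpiperazin-1-yl on an aromatic carbon. The measured steps all concern this carbon, and they show that the three amine substituents lie within a modest span; none of them involves an ether-linked group, so they only bracket the likely range rather than point to a direction. Compound 4 is therefore expected to stay close to compound 3, with a step of a 1.5-fold higher number from compound 3 to compound 4 (0.18 log units; within the scatter) in this assay, giving an estimate of 3 nM with a range from 0.6 nM to 15 nM.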

Compound 4, inhibition constant: 0.5 nM
For compound 4 the middle estimate is 6.0-fold (0.78 log units) above the measured one; the measured number lies below the stated range.
By their numbers in this assay, from the lowest: compounds 1, 4 and 2 (each within the scatter of the next, the first and the last beyond it); then compound 3.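

In this assay, an oxygen-linked group on this aromatic carbon proves compatible with a low number, so a nitrogen attached at this carbon is not required among the compounds shown. Replacing 4-phenylpiperazin-1-yl with (4-fluorobenzyl)oxy gives a step beyond the scatter (a 4.0-fold lower number from compound 3 to compound 4 (0.60 log units; beyond the scatter)), whereas the steps from the two simpler amines stay within it (a 1.4-fold lower number from compound 2 to compound 4 (0.15 log units; within the scatter); a 1.7-fold higher number from compound 1 to compound 4 (0.22 log units; within the scatter)), so compound 4 cannot be ordered against compound 1 or compound 2. For the compounds shown here, compound 3 is now the only compound whose steps to all the others lie beyond the scatter.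

A plain benzyloxy group or a benzylamino group on this carbon would separate the part played by the ring fluorine from that of the oxygen link. No measurement at hand explains why these groups give the numbers they do.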